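A few compounds are considered here, and "the series" means these few. Any claim that something is new, unique, unknown or untested is made for them only; others in the source may bear on it.

Among the measured compounds shown here, compound 2 `COC(=O)[C@@]1(C)CCC=C2[C@@H]1CC[C@@H](C)[C@]2(C)Cc1c(C)[nH]c2c(C)cccc12` is one of two compounds measured in a functional assay on HeLa cells (Homo sapiens) for inhibition, read by sulforhodamine B assay, with a stated time of 48 h (on this read-out higher numbers stand for weaker inhibition of growth and lower numbers for stronger inhibition of growth), where compound 2 gives 14000 nM. Compound 1 `COC(=O)[C@@]1(C)CCC=C2[C@@H]1CC[C@@H](C)[C@]2(C)Cc1c[nH]c2c(Br)cccc12` gives 13000 nM in this assay, and the two numbers lie within the usual scatter of each other, so compound 2 stands alongside compound 1 rather than apart from it. Compound 3 `COC(=O)[C@@]1(C)CCC=C2[C@@H]1CC[C@@H](C)[C@]2(C)Cc1c(C)[nH]c2c(Br)cccc12` differs from compound 2 by bromo in place of methyl on an aromatic carbon. For the measured compounds named here, no step between measured compounds covers this exchange, but compound 1 already carries bromo at that carbon and shows 13000 nM, so no step beyond the scatter is expected in this assay. The estimate is that the change from compound 2 to compound 3 amounts to a 1.1-fold lower number from compound 2 to compound 3 (0.03 log units; within the scatter), giving compound 3 an expected value of 13000 nM, within a range from 6000 nM to 30000 nM.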

Compound 3, concentration for 50% growth inhibition: 22000 nM
Compound 3: middle estimate off by 1.7-fold (0.23 log units), on the low side, and the stated range covers the measured number.
By their numbers in this assay, from the lowest: compounds 1, 2 and 3 (each within the scatter of the next).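

Bromo in place of methyl on the aromatic carbon, ortho to a fused ring, gives a 1.6-fold higher number from compound 2 to compound 3 (0.20 log units; within the scatter) in this assay, and methyl in place of hydrogen on another aromatic carbon gives a 1.7-fold higher number from compound 1 to compound 3 (0.23 log units; within the scatter). Among the compounds shown here, the first direct readings of these two changes therefore show that neither moves the read-out beyond the scatter. Nothing available explains these numbers. As far as these compounds go, whether an amine, a carboxylic acid or a methoxy group at the same carbon would give a step beyond the scatter remains open.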